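The source may hold more compounds than are shown below. What is called first, only, known or untested is meant among the compounds shown, and "the series" means these compounds.

Compound 1 `CS(=O)(=O)N(CC1CC1)c1ccccc1N1CCN(C(=O)[C@H](CC(=O)N2CCNCC2)Cc2ccc(Cl)cc2)CC1`: 220 nM
Compound 2 `CCN1CCN(C(=O)C[C@H](Cc2ccc(Cl)cc2)C(=O)N2CCN(c3ccccc3N(CC3CC3)S(C)(=O)=O)CC2)CC1`: 9.5 nM
Compound 3 `CS(=O)(=O)N(CC1CC1)c1ccccc1N1CCN(C(=O)[C@H](CC(=O)N2CCN(C(=O)c3ccccc3)CC2)Cc2ccc(Cl)cc2)CC1`: 4.4 nM

In an assay on isolated protein for binding affinity to Melanocortin receptor 4 (Homo sapiens) (a higher number here means a weaker inhibitor, a lower number a stronger inhibitor), compound 3 gives the lowest number of the three, set apart by a 2.2-fold lower number from compound 2 to compound 3 (0.33 log units; beyond the scatter) and by a 50-fold lower number from compound 1 to compound 3 (1.70 log units; beyond the scatter). Compound 4 `CC(C)(C)CC(=O)N1CCN(C(=O)C[C@H](Cc2ccc(Cl)cc2)C(=O)N2CCN(c3ccccc3N(CC3CC3)S(C)(=O)=O)CC2)CC1` differs from compound 3 by neopentyl in place of phenyl on a carbonyl carbon: the amide on the ring nitrogen stays, only its carbon part changes. Going by the values given here, no measured step exchanges one such carbonyl group for another. The steps that touch this ring nitrogen, a 23-fold lower number from compound 1 to compound 2 (1.36 log units; beyond the scatter) and a 50-fold lower number from compound 1 to compound 3 (1.70 log units; beyond the scatter), are large when a group replaces hydrogen, while a 2.2-fold lower number from compound 2 to compound 3 (0.33 log units; beyond the scatter) is only a modest gap between two different groups. A modest step at most is therefore expected in this assay, in either direction. Compound 4 is estimated at 6 nM, within 2 nM to 20 nM, meaning a 1.4-fold higher number from compound 3 to compound 4 (0.13 log units; within the scatter).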

Compound 4, half-maximal inhibitory concentration: < 0.1 nM
Compound 4: no number, only a limit; the forecaster's own chance of this, stated with the estimate: 0%; at least 60-fold (1.77 log units) between middle value and limit.
By their numbers in this assay, from the lowest: compound 3; then compound 2; then compound 1. At a limit, below all of these: compound 4.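

In this assay compound 4 gives < 0.1 nM, which is a limit of the assay and not a number. Exchanging only the carbon part of the amide on this ring nitrogen gives an at least 44-fold lower number from compound 3 to compound 4 (1.64 log units; beyond the scatter), alongside an at least 95-fold lower number from compound 2 to compound 4 (1.97 log units; beyond the scatter) and an at least 2200-fold lower number from compound 1 to compound 4 (3.34 log units; beyond the scatter). The earlier exchange between two groups here gave only a 2.2-fold lower number from compound 2 to compound 3 (0.33 log units; beyond the scatter), so what the carbonyl carries can matter far more than those compounds showed.

Which feature of neopentyl counts stays open, since none of the compounds shown carries a straight butyl chain or a cyclohexyl group on this carbonyl. As far as these compounds go, how far the true value of compound 4 lies past its limit also stays open.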